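A Methyl on the Aromatic Ring: Expectation for Compound 4

This account rests on a few compounds, and the source may have more. Where it says the series, first, only, none or still open, it means among the compounds named here.

The measured compounds and their numbers in an assay on blood for inhibition of C-X-C chemokine receptor type 3 (Homo sapiens), with a stated time of 30 min; a higher number here means a weaker inhibitor, a lower number a stronger inhibitor:
compound 1 `O=C(Cn1cnc2cccnc21)N1CCN(c2scnc2-c2nc3ccccc3[nH]2)CC1` gives 1440 nM
compound 2 `C[C@@H]1CN(c2scnc2-c2nc3ccccc3[nH]2)CCN1C(=O)Cn1cnc2cccnc21` gives 554 nM
compound 3 `CC[C@@H]1CN(c2scnc2-c2nc3ccccc3[nH]2)CCN1C(=O)Cn1cnc2cccnc21` gives 851 nM

Compound 2 has the lowest of the three numbers. The step of a 2.6-fold lower number from compound 1 to compound 2 (0.41 log units; beyond the scatter) lies beyond the scatter, whereas a 1.5-fold higher number from compound 2 to compound 3 (0.19 log units; within the scatter) and a 1.7-fold lower number from compound 1 to compound 3 (0.23 log units; within the scatter) both stay within it, so compound 2 and compound 3 cannot be told apart on these data.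

Compound 4 `Cc1nc(-c2nc3ccccc3[nH]2)c(N2CCN(C(=O)Cn3cnc4cccnc43)[C@H](C)C2)s1` differs from compound 2 by methyl in place of hydrogen on an aromatic carbon. Among the measured compounds shown here, none of the measured steps bears on this position: a 2.6-fold lower number from compound 1 to compound 2 (0.41 log units; beyond the scatter) and a 1.7-fold lower number from compound 1 to compound 3 (0.23 log units; within the scatter) each add an alkyl group on a saturated ring carbon of the shared core, and a 1.5-fold higher number from compound 2 to compound 3 (0.19 log units; within the scatter) extends such a group on a saturated chain carbon. The aromatic carbon that receives the methyl in compound 4 is untouched in every measured compound, so there is no direct guide to the size or direction of the change.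

In the absence of such a guide, the step is expected to fall within the scatter, that is a 1.0-fold lower number from compound 2 to compound 4 (0.00 log units; within the scatter). The estimate for compound 4 in this assay is therefore 550 nM, with a range from 230 nM to 1300 nM.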

Compound 4, half-maximal inhibitory concentration: 1060 nM
Compound 4: middle estimate off by 1.9-fold (0.28 log units), on the low side, and the stated range covers the measured number.
By their numbers in this assay, from the lowest: compounds 2, 3, 4 and 1 (each within the scatter of the next, the first and the last beyond it).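

In this assay, among the compounds shown here, the methyl on the aromatic carbon of the five-membered aromatic ring with 1 nitrogen and 1 sulfur gives the first reading at this position, since compound 1, compound 2 and compound 3 differ only at saturated carbons, and the result is a 1.9-fold higher number from compound 2 to compound 4 (0.28 log units; within the scatter). The two compounds therefore cannot be told apart, so on the background of compound 2 a single methyl placed next to the ring nitrogen and next to the ring sulfur brings no change that stands out from repeat measurements. No available evidence bears on this result.

On these data alone, one methyl says little about the position as a whole, and how an ethyl, a longer chain, an amine or a carboxylic acid on this aromatic carbon would read remains open. Also open, as far as these compounds go, is whether the methyl would give a similar step on the core of compound 1, which lacks the methyl on the saturated ring carbon, or on that of compound 3, which carries an ethyl there.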